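Smaller fluorophenyl on the ring nitrogen: compound 4

The compounds below may be only part of what the source reports. "The series", "measured", "known", "first", "only" and "open" are said of these compounds alone.

Three compounds have been measured in a functional assay on CHO cells with adenosine receptor A1 (Homo sapiens) as the target, read by cAMP accumulation and immunoassay, with a stated time of 6 min, tested at 0.1 uM; a lower number here means a stronger effect, a higher number a weaker effect of the compound at the concentration tested:
compound 1 `Nc1scc(CN2CCN(c3ccc(F)cc3Cl)CC2)c1C(=O)c1ccc(Cl)cc1` gives -6.2%
compound 2 `COc1ccc(N2CCN(Cc3csc(N)c3C(=O)c3ccc(Cl)cc3)CC2)cc1` gives 0%
compound 3 `Nc1scc(CN2CCN(c3ccc(Cl)c(C(F)(F)F)c3)CC2)c1C(=O)c1ccc(Cl)cc1` gives -12%

Compound 3 has the lowest number of the three, but its step from compound 1 is small: a number 5.8 percentage points lower from compound 1 to compound 3 (within the scatter). Only its step from compound 2 stands beyond the scatter: a number 12 percentage points lower from compound 2 to compound 3 (beyond the scatter). Compound 4 `Nc1scc(CN2CCN(c3cccc(F)c3)CC2)c1C(=O)c1ccc(Cl)cc1` is not yet measured. It differs from compound 3 in one place: 3-fluorophenyl in place of 4-chloro-3-(trifluoromethyl)phenyl on an amine nitrogen in a ring. Among the measured compounds shown here, the steps that bear on this change are the two that also replace the group on that ring nitrogen, a number 6.2 percentage points higher from compound 1 to compound 2 (within the scatter) and a number 5.8 percentage points lower from compound 1 to compound 3 (within the scatter), both within the scatter, and the modest step of a number 12 percentage points lower from compound 2 to compound 3 (beyond the scatter). Since every exchange of this group has shifted the number by only a little, no step beyond the scatter is expected; the expected step is a number 8 percentage points higher from compound 3 to compound 4 (within the scatter). Compound 4 is therefore estimated to give -4%, within a range from -16% to 8%.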

Compound 4, a percentage reported as activity, at one concentration (the size of the read-out at that concentration, not a potency): -37%
Compound 4: middle estimate off by 33 percentage points, on the high side, outside the stated range (below it).
By their numbers in this assay, from the lowest: compound 4; then compounds 3, 1 and 2 (each within the scatter of the next, the first and the last beyond it).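

The group on the ring nitrogen matters more than the first three compounds suggested, since replacing 4-chloro-3-(trifluoromethyl)phenyl, with 11 heavy atoms, by 3-fluorophenyl, with 7, gives a number 25 percentage points lower from compound 3 to compound 4 (beyond the scatter) in this assay. The other two groups compare the same way with 3-fluorophenyl: the change gives a number 30.8 percentage points lower from compound 1 to compound 4 (beyond the scatter) and a number 37 percentage points lower from compound 2 to compound 4 (beyond the scatter), so compound 4 stands apart from all three earlier compounds. Nothing measured here explains why this group stands apart.

From the compounds shown here alone, whether the fluorine itself is needed stays open, and a plain phenyl or a benzyl group on the same nitrogen would test how far the result depends on it. Going by these compounds, these are readings at a single concentration, so how the compounds compare in potency also remains unknown.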